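Swapping the ring on the amide-side chain carbon

The source may report more compounds than this note shows. Statements on the series, on what has been measured and on what is new or still open speak of the compounds shown alone.

Measured so far:
compound 1 `Cc1nc(N)sc1CCCN/C(N)=N/C(=O)NC(C)c1cccc(F)c1` with 2.04 nM in an assay on membranes from Sf9 cells for displacement of a labelled ligand from histamine H2 receptor (Homo sapiens), read by scintillation counting, with a stated time of 60 min; a lower number here means a stronger inhibitor, a higher number a weaker inhibitor
compound 2 `Cc1nc(N)sc1CCCN/C(N)=N/C(=O)NC(C)c1ccc(Br)cc1` with 30.2 nM
compound 3 `Cc1nc(N)sc1CCCN/C(N)=N/C(=O)NC(C)c1ccccc1F` with 28.8 nM

Compound 3 holds the second highest number of the three. Its nearest neighbour is compound 2, where the gap a 1.0-fold lower number from compound 2 to compound 3 (0.02 log units; within the scatter) lies within the scatter, so the two cannot be ranked. Its furthest neighbour is compound 1, reached by a 14-fold higher number from compound 1 to compound 3 (1.15 log units; beyond the scatter), a large gap.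

Compound 4 `Cc1nc(N)sc1CCCN/C(N)=N/C(=O)NC(C)c1ccc(Cl)cc1` differs from compound 3 in one place: 4-chlorophenyl in place of 2-fluorophenyl on a saturated chain carbon bound to an amide-type nitrogen and a saturated chain carbon. Among the measured compounds shown here, no measured step involves 4-chlorophenyl directly. The closest guide is compound 2, whose 4-bromophenyl sits at the same place; the step of a 15-fold higher number from compound 1 to compound 2 (1.17 log units; beyond the scatter) shows that this ring and 2-fluorophenyl both give large rises from compound 1, and the step of a 1.0-fold lower number from compound 2 to compound 3 (0.02 log units; within the scatter) shows that the two end up close to each other. Compound 4 is therefore expected to sit near compound 2 and compound 3, with a step of a 1.0-fold higher number from compound 3 to compound 4 (0.02 log units; within the scatter) that stays within the scatter. The estimate for compound 4 is 30 nM, in a range from 12 nM to 80 nM.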

Compound 4, inhibition constant: 46.8 nM
The estimate for compound 4 lay 1.6-fold (0.19 log units) below the measured number; low and high end bracket the measured number.
By their numbers in this assay, from the lowest: compound 1; then compounds 3, 2 and 4 (each within the scatter of the next).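

In this assay, chloro in place of bromo on the ring gives two compounds that cannot be ranked (a 1.5-fold higher number from compound 2 to compound 4 (0.19 log units; within the scatter)), so these two halogens are not told apart here. 4-Chlorophenyl also cannot be ranked against 2-fluorophenyl (a 1.6-fold higher number from compound 3 to compound 4 (0.21 log units; within the scatter)), yet it lies far from 3-fluorophenyl (a 23-fold higher number from compound 1 to compound 4 (1.36 log units; beyond the scatter)), so three of the four rings shown form one group, and only compound 1 stands apart, with the lowest number. Nothing measured here explains that gap.

From the compounds shown here alone, it remains open whether the low number of compound 1 goes with fluorine itself or with the place it holds on the ring, which a chloro group in that same place would help to settle. Also open, going by these compounds, is how a plain phenyl ring, or a ring carrying a methoxy group, would compare.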